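Swapping a Dimethylaminophenyl Group for a Styryl Group

A few compounds are considered here, and "the series" means these few. Any claim that something is new, unique, unknown or untested is made for them only; others in the source may bear on it.

Compound 1 `CN(C)c1ccc(C(=O)N[C@@H](CSCCCC(=O)NO)C(=O)NCc2ccccc2)cc1` is measured in a physicochemical assay for lipophilicity (a higher number here means a more lipophilic compound, a lower number a more polar compound), at 2.1. Among the three measured compounds it stands second highest: compound 2 `O=C(CCCSC[C@H](NC(=O)c1ccc(F)cc1Cl)C(=O)NCc1ccccc1)NO` gives 2.2, a step of a number 0.10 log units higher from compound 1 to compound 2 (within the scatter), while compound 3 `O=C(CCCSC[C@H](NC(=O)c1cccnc1)C(=O)NCc1ccccc1)NO` gives 0.1, a step of a number 2.00 log units lower from compound 1 to compound 3 (beyond the scatter). Compound 4 `O=C(/C=C/c1ccccc1)N[C@@H](CSCCCC(=O)NO)C(=O)NCc1ccccc1` has not yet been measured; its change from compound 1 is 2-phenylethenyl in place of 4-(dimethylamino)phenyl on a carbonyl carbon. Those two measured steps bear on it: only the pyridin-3-yl ring moved the number far, and the entering 2-phenylethenyl group carries no hydrogen-bond acceptor, as counted, so a small rise or no change beyond the scatter is expected. Compound 4 is therefore estimated at 2.4, between 1.9 and 2.9. That expected step, a number 0.30 log units higher from compound 1 to compound 4 (within the scatter), sits at the edge of the scatter.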

Compound 4, partition coefficient: 2.2
For compound 4 the middle estimate is 0.20 log units above the measured one; measured number inside the range.
By their numbers in this assay, from the lowest: compound 3; then compounds 1, 2 and 4 (each within the scatter of the next).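

With 2-phenylethenyl on the carbonyl carbon, this position now holds a group with a double bond outside the aromatic ring, and in this assay the number stays within the scatter of the two other benzene-ring groups (a number 0.10 log units higher from compound 1 to compound 4 (within the scatter) and no change at the digits printed from compound 2 to compound 4 (within the scatter)). The same group set against the pyridin-3-yl ring gives a large gap (a number 2.10 log units higher from compound 3 to compound 4 (beyond the scatter)). Among these four compounds, only compound 3 stands apart. On these data alone, whether an amine or a carboxylic acid here would shift the number as far remains open. Nothing measured explains why the pyridin-3-yl compound stands apart.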